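A few compounds are considered here, and "the series" means these few. Any claim that something is new, unique, unknown or untested is made for them only; others in the source may bear on it.

Of the compounds shown here, three sharing one core have been tested in a toxicity assay on MT2 cells (Homo sapiens) for cytotoxicity; a lower number here means that less compound is tolerated, a higher number that more compound is tolerated. Compound 1 `Cc1nc(C)c([C@H](OC(C)(C)C)C(=O)O)c(N2CCC(C)(C)CC2)c1C1=CCN(CCCc2ccc(F)cc2)CC1` gives >= 22000 nM, which is a limit of the assay and not a number. Compound 2 `Cc1nc(C)c([C@H](OC(C)(C)C)C(=O)O)c(N2CCC(C)(C)CC2)c1-c1cnn(CCCc2ccc(F)cc2)c1` gives >= 22000 nM, again a limit. Compound 3 `Cc1cccc(F)c1CN1CCc2cc(-c3c(C)nc(C)c([C@H](OC(C)(C)C)C(=O)O)c3N3CCC(C)(C)CC3)ccc2C1` gives >= 24000 nM, also a limit. Compound 3 therefore has no exact number, and neither do the other two: the limit of >= 22000 nM in this assay, at which 2 of the 3 values shown sit, and (the limit of >= 24000 nM in this assay, at which 1 of the 3 values shown sits).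

Compound 4 `Cc1nc(C)c([C@H](OC(C)(C)C)C(=O)O)c(N2CCC(C)(C)CC2)c1-c1ccc2c(c1)CCN(c1ncnc3c1cnn3C)C2` has not yet been measured. It keeps the core of compound 3 and exchanges one group: a group of 10 heavy atoms (6 carbon, 4 nitrogen; one five-membered aromatic ring with 2 hetero atoms, one six-membered aromatic ring with 2 hetero atoms) in place of a group of 9 heavy atoms (8 carbon, 1 fluorine; one six-membered aromatic ring of carbon only), on an amine nitrogen in a ring. For the measured compounds named here, no measured step is available to show what such an exchange does. The three tested compounds differ in structure, yet each of them gives only a limit. The expectation therefore rests on compound 3 at >= 24000 nM, a limit. No change beyond the scatter is expected, and the estimated step is a number no higher from compound 3 to compound 4 (the limit leaves the size open). For compound 4 the estimated value is 24000 nM, with an expected range from 10000 nM to 50000 nM.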

Compound 4, half-maximal cytotoxic concentration: >= 17000 nM
Compound 4 gave a limit, no number; the forecaster's own chance of this, stated with the estimate: 75%; the middle value does not contradict the limit.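

In this assay compound 4 gives >= 17000 nM, which is a limit and not a number. Compound 3 also gives only a limit, and the step between these two compounds cannot be read. The compounds shown leave open what exact concentration of any of them is half-maximally cytotoxic, and whether exchanging the group on the ring nitrogen alters it.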